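The compounds below may be only part of what the source reports. "The series", "measured", "known", "first", "only" and "open" are said of these compounds alone.

Going by the values given here, in a functional assay on A549 cells (Homo sapiens) for antiproliferative activity, read by MTT assay, with a stated time of 48 h (on this read-out higher numbers stand for weaker inhibition and lower numbers for stronger inhibition), three compounds sharing one core have numbers so far. Compound 1 `COc1ccc(-c2cc3c(cn2)[nH]c(=O)n3-c2cc(OC)c(OC)c(OC)c2)cc1` gives 1120 nM, compound 2 `COc1ccc(-c2cc3c(cn2)[nH]c(=O)n3-c2cc(OC)c(OC)c(OC)c2)cc1F` gives 2020 nM, and compound 3 `CCOc1ccc(-c2cc3c(cn2)[nH]c(=O)n3-c2cc(OC)c(OC)c(OC)c2)cc1F` gives 2540 nM. The data show a 1.3-fold higher number from compound 2 to compound 3 (0.10 log units; within the scatter), so those two cannot be told apart, but they also show a 2.3-fold higher number from compound 1 to compound 3 (0.36 log units; beyond the scatter).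

Compound 4 `COc1ccc(-c2cc3c(cn2)[nH]c(=O)n3-c2cc(OC)c(OC)c(OC)c2)cc1C` has not been measured yet. The change is 4-methoxy-3-methylphenyl in place of 4-ethoxy-3-fluorophenyl on an aromatic carbon. Among the compounds with values here, no measured compound carries this new group, so the evidence is indirect. Two measured steps cover what is removed. Putting fluoro in place of hydrogen gave a 1.8-fold higher number from compound 1 to compound 2 (0.26 log units; within the scatter), and extending methoxy to ethoxy gave a 1.3-fold higher number from compound 2 to compound 3 (0.10 log units; within the scatter). Going by these compounds, both are small, and undoing them would point toward compound 1, though the effect of the added methyl is unknown. The expected change is therefore modest, toward a lower number: a 1.7-fold lower number from compound 3 to compound 4 (0.23 log units; within the scatter). Compound 4 is estimated at 1500 nM, with an expected range from 700 nM to 3200 nM.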

Compound 4, half-maximal inhibitory concentration: 1910 nM
The estimate for compound 4 lay 1.3-fold (0.10 log units) below the measured number; the measured number falls inside the stated range.
By their numbers in this assay, from the lowest: compounds 1, 4, 2 and 3 (each within the scatter of the next, the first and the last beyond it).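

In this assay, methyl in place of fluoro on the aromatic carbon gives a 1.1-fold lower number from compound 2 to compound 4 (0.02 log units; within the scatter) and so leaves the two groups indistinguishable on this read-out. Methyl in place of hydrogen gives a 1.7-fold higher number from compound 1 to compound 4 (0.23 log units; within the scatter) and stays within the scatter, and so does the exchange of the whole 4-ethoxy-3-fluorophenyl group for 4-methoxy-3-methylphenyl, which gives a 1.3-fold lower number from compound 3 to compound 4 (0.12 log units; within the scatter) and adds to the picture of a read-out that barely separates these small changes on the phenyl ring.

Still open, going by these compounds, is whether a quite different group on that ring, such as an amine, a carboxylic acid or a nitrile, would shift the number beyond the scatter. A longer chain on the ring oxygen, such as propoxy, is equally untested in the compounds shown. No measurement among these compounds offers an explanation for these numbers.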